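Working notes on a side-chain swap and cytotoxicity

The source may hold more compounds than are shown below. What is called first, only, known or untested is meant among the compounds shown, and "the series" means these compounds.

Compound 1 `Nc1nc(OCc2ccccc2)c2ncn(/C=C3/CC3(CO)CO)c2n1` and compound 2 `CCCCCCCCSc1nc(N)nc2c1ncn2/C=C1/CC1(CO)CO` share one core and differ on a single aromatic carbon, where octylsulfanyl stands in place of benzyloxy. In an ADME assay on BCBL1 cells (Homo sapiens) for cytotoxicity, with a stated time of 7 days (on this read-out higher numbers stand for lower toxicity in this test and lower numbers for higher toxicity in this test), compound 1 gives only a limit, > 20000 nM. In this assay compound 2 likewise gives only a limit, > 20000 nM. The step that the two limits leave unreadable from compound 1 to compound 2 can therefore not be read in size; the whole picture so far is the limit of > 20000 nM in this assay, at which 2 of the 2 values shown sit. Compound 2 thus stands at the limit of this assay without a number of its own.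

Compound 3 `CCCCCCOc1nc(N)nc2c1ncn2/C=C1/CC1(CO)CO` differs from compound 2 by hexyloxy in place of octylsulfanyl on an aromatic carbon. Among the compounds with values here, the one measured step concerns a different change and is itself unreadable, so no step of known size bears on this swap. The expected step in this assay is accordingly none beyond the scatter, a step that the limit leaves unreadable from compound 2 to compound 3. Compound 3 is estimated at 25000 nM in this assay, within a range from 10000 nM to 60000 nM, and is expected most likely to be reported again as a limit rather than as a number.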

Compound 3, half-maximal cytotoxic concentration: > 20000 nM
Compound 3: no number, only a limit; the forecaster's own chance of this, stated with the estimate: 80%; the middle value lies beyond the limit too.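

Compound 3 also gives only a limit in this assay, so the steps that link it to compound 1 and compound 2 cannot be read, and no new step follows: the limit of > 20000 nM in this assay, at which 3 of the 3 values shown sit.

The compounds shown leave open how compound 1, compound 2 and compound 3 compare in this assay, and whether swapping these side chains changes the read-out at all.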